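Methoxy in place of ethyl: notes on four compounds

The source may hold more compounds than are shown below. What is called first, only, known or untested is meant among the compounds shown, and "the series" means these compounds.

Compound 3 `CCc1nc(-c2ccc(Cl)cc2Cl)c(CC)nc1NC(CC)CC` and compound 1 `CCc1nc(NC(CC)CC)c(OC)nc1-c1ccc(Cl)cc1Cl` differ in one place: methoxy in place of ethyl on an aromatic carbon. In an assay on IMR-32 cells for displacement of a labelled ligand from corticotropin-releasing factor receptor 1 (Homo sapiens), read by scintillation counting, with a stated time of 2 h (on this read-out lower numbers stand for stronger inhibition and higher numbers for weaker inhibition), compound 3 gives 4.1 nM and compound 1 gives 5.9 nM, a step of a 1.4-fold higher number from compound 3 to compound 1 (0.16 log units; within the scatter). Compound 2 `CCc1nc(-c2ccc(OC)cc2C(F)(F)F)c(CC)nc1NC(CC)CC` gives 4.4 nM in this assay; the difference between the cores of compound 2 and compound 3 is not broken down here. Compound 4 `CCc1nc(NC(CC)CC)c(OC)nc1-c1ccc(OC)cc1C(F)(F)F` is not yet measured and differs from compound 2 by methoxy in place of ethyl on an aromatic carbon. This is the same kind of change as from compound 3 to compound 1, though here the place is meta to a large group rather than meta to a 2,4-dichlorophenyl group. Because a 1.4-fold higher number from compound 3 to compound 1 (0.16 log units; within the scatter) lies within the scatter, the step from compound 2 to compound 4 in this assay is expected to be a 1.3-fold higher number from compound 2 to compound 4 (0.12 log units; within the scatter). Compound 4 is estimated at 5.8 nM, within a range from 2.5 nM to 14 nM.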

Compound 4, inhibition constant: 2.2 nM
For compound 4 the middle estimate is 2.6-fold (0.42 log units) above the measured one, and the stated range ends above it.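

In this assay, methoxy in place of ethyl does not act as one fixed step across these two cores: the same change on two cores in this assay, a 1.4-fold higher number (0.16 log units; within the scatter) from compound 3 to compound 1 and a 2.0-fold lower number (0.30 log units; within the scatter) from compound 2 to compound 4, 2.9-fold (0.46 log units) apart, beyond the scatter of two such steps

Read alone, a 2.0-fold lower number from compound 2 to compound 4 (0.30 log units; within the scatter) stays within the scatter, so the difference between the cores shows only when the two steps are set side by side. The two pairs show that the outcome of this change depends on the core, but not which feature of the cores accounts for that, nor how it would run on a third core.

Still open, as far as these compounds go, is whether the gap persists with other groups in place of ethyl, such as an amine, a nitrile or a longer alkoxy chain. Also open, from the compounds shown here alone, is whether it holds when the (pentan-3-yl)amino group is replaced by a different amine.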